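The source may report more compounds than this note shows. Statements on the series, on what has been measured and on what is new or still open speak of the compounds shown alone.

Of the compounds shown here, three built on a shared core have been measured in a functional assay on HT-29 cells (Homo sapiens) for cytotoxicity, read by MTT assay, with a stated time of 24 h, tested at 80 ug/mL; on this read-out higher numbers stand for a stronger effect at the one concentration tested and lower numbers for a weaker effect. Compound 1 `Cn1c(-c2ccc(NC(=O)CSc3nc4cc(Cl)ccc4o3)cc2)nc(-c2ccccc2)c1-c1ccccc1` gives 79.6%, compound 2 `Cn1c(-c2ccc(NC(=O)CSc3nc4ccccc4s3)cc2)nc(-c2ccccc2)c1-c1ccccc1` gives 82.7% and compound 3 `Cn1ccnc1SCC(=O)Nc1ccc(-c2nc(-c3ccccc3)c(-c3ccccc3)n2C)cc1` gives 69.4%. Compound 3 therefore stands lowest of the three, with steps beyond the scatter to both of the others: a number 10.2 percentage points lower from compound 1 to compound 3 (beyond the scatter) and a number 13.3 percentage points lower from compound 2 to compound 3 (beyond the scatter). Between the other two the gap is within the scatter, a number 3.1 percentage points higher from compound 1 to compound 2 (within the scatter).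

Compound 4 `CN(C)/C=C/N1CCN(CC(=O)Nc2ccc(-c3nc(-c4ccccc4)c(-c4ccccc4)n3C)cc2)CC1` has not yet been measured in this assay. It differs from compound 3 in one place: 4-(2-(dimethylamino)ethenyl)piperazin-1-yl in place of (1-methyl-1H-imidazol-2-yl)sulfanyl on a saturated chain carbon bound to a carbonyl carbon. The change removes the sulfur link and the five-membered aromatic ring together and brings in a six-membered non-aromatic ring that carries a double bond outside aromatic rings.

Among the compounds with values here, none of the measured steps covers a change of this kind. The two that bear on it, a number 10.2 percentage points lower from compound 1 to compound 3 (beyond the scatter) and a number 13.3 percentage points lower from compound 2 to compound 3 (beyond the scatter), show only that putting 1-methyl-1H-imidazol-2-yl on the sulfur in place of either bicyclic group brought a modest loss. Compound 4 goes further and drops the sulfur-linked ring altogether, with no direct comparison to lean on. The expected step in this assay is therefore a small further decrease or none beyond the scatter, a number 7.4 percentage points lower from compound 3 to compound 4 (within the scatter). Compound 4 is estimated to give 62%, within a range from 45% to 78%.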

Compound 4, a percentage reported as activity, at one concentration (the size of the read-out at that concentration, not a potency): 45.4%
Compound 4: the middle estimate sits 16.6 percentage points above what was measured; the range from low to high includes it.
By their numbers in this assay, from the lowest: compound 4; then compound 3; then compounds 1 and 2 (each within the scatter of the next).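

In this assay, within the data shown here, the earlier steps changed only the ring held on the sulfur, whereas this change replaces the sulfur link as well, and the read-out falls further on the saturated chain carbon bound to a carbonyl carbon (in numbers: a number 24 percentage points lower from compound 3 to compound 4 (beyond the scatter)). The same replacement measured against the two bicyclic sulfur-linked groups gives the largest steps in the set (a number 37.3 percentage points lower from compound 2 to compound 4 (beyond the scatter) and a number 34.2 percentage points lower from compound 1 to compound 4 (beyond the scatter)), so among these four compounds the sulfur-linked rings all stand higher than the 4-(2-(dimethylamino)ethenyl)piperazin-1-yl group. Nothing available here explains why the read-out drops with this group.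

Because the sulfur link, the aromatic ring and the ethenyl side chain all change at once, the compounds shown leave open which of these parts matters for the drop. A plain piperazin-1-yl group, a 4-methylpiperazin-1-yl group or a simple dimethylamino group at the same place would help separate those parts, as would a morpholine ring, which would show whether the second ring nitrogen matters.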